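The source may hold more compounds than are shown below. What is called first, only, known or untested is meant among the compounds shown, and "the series" means these compounds.

Of the compounds shown here, three from this series have been tested in an ADME assay on SH-SY5Y cells (Homo sapiens) for inhibition, read by MTT assay, with a stated time of 72 h; a higher number here means a weaker inhibitor, a lower number a stronger inhibitor. Compound 1 `CN(c1ccccc1)S(=O)(=O)c1ccc2c(c1)sc(=O)n2CCN1CCCC1` gives 49500 nM, compound 2 `CN(C)CCn1c(=O)sc2cc(S(=O)(=O)N(C)c3cccc4ccccc34)ccc21` gives 29000 nM, and compound 3 `O=c1sc2cc(S(=O)(=O)Nc3ccccc3)ccc2n1CCN1CCCC1` gives 10000 nM. Compound 1 and compound 3 differ in a single place: hydrogen in place of methyl on a sulfonamide nitrogen This change brings a 5.0-fold lower number from compound 1 to compound 3 (0.69 log units; beyond the scatter). Compound 2 and compound 1 differ by more than one place, and the difference between the two cores is not broken down here; their values lie within the scatter of one another, so no order between them is claimed.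

Compound 4 `CN(C)CCn1c(=O)sc2cc(S(=O)(=O)Nc3cccc4ccccc34)ccc21` has not yet been measured. It stands to compound 2 as compound 3 stands to compound 1: hydrogen in place of methyl on a sulfonamide nitrogen The place of the change is the same in both pairs, so the change itself is the same. Resting on the single measured step, compound 4 is expected to give 5800 nM in this assay, within a likely range of 2500 nM to 13500 nM. The expected step is therefore a 5.0-fold lower number from compound 2 to compound 4 (0.70 log units; beyond the scatter), taken as roughly the size seen from compound 1 to compound 3, with the caution that a single pair is a thin basis.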

Compound 4, half-maximal inhibitory concentration: 45700 nM
The estimate for compound 4 lay 7.9-fold (0.90 log units) below the measured number; the measured number lies above the stated range.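

On the core of compound 2, hydrogen in place of methyl on a sulfonamide nitrogen brings a 1.6-fold higher number from compound 2 to compound 4 (0.20 log units; within the scatter), so the lowering seen on the core of compound 1 does not reappear. Set side by side in this assay, the two steps do not agree: the same change on two cores in this assay, a 5.0-fold lower number (0.69 log units; beyond the scatter) from compound 1 to compound 3 and a 1.6-fold higher number (0.20 log units; within the scatter) from compound 2 to compound 4, 7.8-fold (0.89 log units) apart, beyond the scatter of two such steps This shows that the step measured on one core cannot simply be carried to the other in this series, but with only two pairs it does not show which of the several differences between the cores goes with the different outcome, nor how the change would behave on any further core.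

The compounds shown leave open whether the step on the core of compound 1 or the step on the core of compound 2 is the more typical for this series. They also leave open what an ethyl group or an acetyl group would do in place of methyl on a sulfonamide nitrogen on either core.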